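This account rests on a few compounds, and the source may have more. Where it says the series, first, only, none or still open, it means among the compounds named here.

Series notes. In an assay on HL-60 cells for agonist activity at vitamin D3 receptor (Homo sapiens), read by microscopy, with a stated time of 96 h (a higher number here means that more compound is needed for the effect, a lower number that less compound is needed), compound 1 `CCn1c(C(=O)N(C)c2ccccc2)ccc1C(CC)(CC)c1ccc(OCC(=O)C(C)(C)C)c(C)c1` gives 18500 nM, while compound 2 `C#CC(C)OC(=O)c1ccc(C(CC)(CC)c2ccc(OCC(=O)C(C)(C)C)c(C)c2)n1CC` gives 210 nM. Among the compounds with values here, the single step between them, an 88-fold lower number from compound 1 to compound 2 (1.94 log units; beyond the scatter), exchanges the amide on the carbonyl carbon for an ester. Among the two numbers in hand compound 2 stands lowest, with compound 1 its only neighbour and far from it. Compound 3 `CCn1c(C(=O)Nc2ccc(OC(F)(F)F)cc2)ccc1C(CC)(CC)c1ccc(OCC(=O)C(C)(C)C)c(C)c1` is not yet measured in this assay. It differs from compound 2 by (4-(trifluoromethoxy)phenyl)amino in place of (1-methylprop-2-yn-1-yl)oxy on a carbonyl carbon. Within the data shown here, the only step that bears on this change is an 88-fold lower number from compound 1 to compound 2 (1.94 log units; beyond the scatter), a large one; compound 3 moves back from the ester to an amide, now bearing a hydrogen-bond donor and an aromatic ring, so a return part of the way towards compound 1 is expected, without a basis for saying how much of the distance is recovered. For compound 3 the expected step is a 14-fold higher number from compound 2 to compound 3 (1.15 log units; beyond the scatter), giving an estimate of 3000 nM with a range from 600 nM to 15000 nM.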

Compound 3, half-maximal effective concentration: > 50000 nM
Compound 3: only a limit was reported; the forecaster's own chance of this, stated with the estimate: 5%; middle value at least 16-fold (1.22 log units) away from the limit.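

Compound 3 carries only a limit in this assay, not a number: the limit of > 50000 nM in this assay, at which 1 of the 3 values shown sits. At this carbonyl carbon, (4-(trifluoromethoxy)phenyl)amino in place of (1-methylprop-2-yn-1-yl)oxy gives an at least 230-fold higher number from compound 2 to compound 3 (2.37 log units; beyond the scatter), so an amide with a hydrogen-bond donor also sits far from the ester, and the low number of compound 2 is not reached by this second amide. Against the first amide, the exchange of methyl(phenyl)amino gives an at least 2.7-fold higher number from compound 1 to compound 3 (0.43 log units; beyond the scatter), so among these three compounds the one ester stands apart from the two amides, though this rests on very few examples.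

The compounds shown do not separate the ester link from the (1-methylprop-2-yn-1-yl)oxy group itself; a plain ethyl ester, a carboxylic acid or an amide of a small alkyl amine would bear on that. On these data alone, how far compound 3 lies past its limit also remains unknown.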